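Swapping Cyclohexyl for a Hydroxylated Chain on an Amide

This account rests on a few compounds, and the source may have more. Where it says the series, first, only, none or still open, it means among the compounds named here.

Compound 1, with the structure `COc1cccc2cc(C(=O)NC3CCCCC3)c(=N)oc12`, is the starting point. Going by the values given here, in an assay on HeLa cells for displacement of a labelled ligand from adenosine receptor A3 (Homo sapiens), read by scintillation counting, with a stated time of 180 min, tested at 10 uM (a higher number here means more inhibition at the concentration tested (going by the name of the read-out), a lower number less inhibition), compound 1 gives 16%, the lowest of the three numbers measured so far. The nearest is compound 3, `COc1cccc2c1OC(C)(O)C(C(C)=O)=C2`, which in this assay gives 30%, a difference beyond the usual scatter. The furthest is compound 2, `COC(=O)/C(C#N)=C/c1cccc(OC)c1O`, which in this assay gives 45%, again beyond the scatter. Neither compound 2 nor compound 3 differs from compound 1 in only one place, so their values tell nothing about single changes.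

Compound 4, `CCC(CO)NC(=O)c1cc2cccc(OC)c2oc1=N`, is the next compound to be measured. It differs from compound 1 in one place: 1-(hydroxymethyl)propyl in place of cyclohexyl on an amide-type nitrogen. Among the compounds with values here, no measured pair shows what this change does, so the expectation rests on compound 1 alone. The step from compound 1 to compound 4 in this assay is expected to be a number 2 percentage points higher from compound 1 to compound 4 (within the scatter), that is, no change beyond the scatter in either direction. Compound 4 is therefore expected to give about 18% in this assay, within a range of 5% to 35%.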

Compound 4, a percentage reported as inhibition, at one concentration (the size of the read-out at that concentration, not a potency): 6%
For compound 4 the middle estimate is 12 percentage points above the measured one; measured number inside the range.
By their numbers in this assay, from the lowest: compounds 4 and 1 (each within the scatter of the next); then compound 3; then compound 2.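

In this assay, putting 1-(hydroxymethyl)propyl in place of cyclohexyl on the amide-type nitrogen gives a number 10 percentage points lower from compound 1 to compound 4 (within the scatter). Going by these compounds alone, this is the first single change read on the core of compound 1, and it shows that an open chain with one hydrogen-bond donor and one hydrogen-bond acceptor, in place of a carbon ring with neither, does not move the number beyond the scatter at the one concentration tested. Nothing measured here speaks to why the number stays within the scatter.

The ring leaves and the hydroxyl enters in the same step, so the part played by each cannot be separated. A plain butyl chain without oxygen, or a chain ending in an amine or a carboxylic acid, would be needed to tell whether the number is higher, lower or level with other groups at this position.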